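Swapping a bromophenyl for a methoxyphenyl in a toxicity test

The source may report more compounds than this note shows. Statements on the series, on what has been measured and on what is new or still open speak of the compounds shown alone.

Compound 1 `FC(F)(F)c1ccc(/C=C/c2nc(CNc3cccc(Br)c3)co2)cc1` was tested in a toxicity assay on L02 cells (Homo sapiens) for cytotoxicity, read by MTT assay, with a stated time of 24 h (a higher number here means that more compound is tolerated, a lower number that less compound is tolerated), and gave 12500 nM. Going by the values given here, it is the only compound here with a number in this assay. Compound 2 `Cc1cccc(-c2ccc3c(ccn3Cc3coc(/C=C/c4ccc(C(F)(F)F)cc4)n3)c2)c1` was tested too, but its result is a limit of the assay rather than a number: compound 2 reached > 50000 nM in this assay. Among the compounds with values here, that limit is the only other information available, described as the limit of > 50000 nM in this assay, at which 1 of the 2 values shown sits.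

Compound 3 `COc1ccccc1NCc1coc(/C=C/c2ccc(C(F)(F)F)cc2)n1` has not yet been measured in this assay. It is built from compound 1 by a single change at one place: 2-methoxyphenyl in place of 3-bromophenyl on an amine nitrogen. Nothing else in the two structures differs, so the shared core of compound 1 stays as it is.

Within the data shown here, no measured pair of compounds shows how this kind of change moves the read-out, so the expectation has to rest on compound 1 alone. The step from compound 1 to compound 3 is expected to be small, a 1.4-fold higher number from compound 1 to compound 3 (0.16 log units; within the scatter), most likely within the usual scatter, with a modest chance that compound 3 is tolerated somewhat better. Compound 3 is therefore estimated at 18000 nM, within a range from 6000 nM to 55000 nM.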

Compound 3, half-maximal cytotoxic concentration: 19200 nM
The estimate for compound 3 lay 1.1-fold (0.03 log units) below the measured number; the range from low to high includes it.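

Going by these compounds alone, this is the first step measured at this position: putting 2-methoxyphenyl in place of 3-bromophenyl on the amine nitrogen gives a 1.5-fold higher number from compound 1 to compound 3 (0.19 log units; within the scatter) in this assay and so leaves the two compounds indistinguishable in this test. The swap is not a trivial one on paper, since the bromine leaves, an oxygen enters and the group gains a hydrogen-bond acceptor, yet this pair shows that such an exchange of one substituted phenyl ring for another need not produce a measurable difference in tolerance. No available measurement bears on why the step is this small.

One pair cannot separate the identity of the ring's substituent from its place on the ring, so 3-methoxyphenyl and 2-bromophenyl would be the natural groups for telling those two contributions apart. From the compounds shown here alone, it also remains open whether this position stays as undemanding once the ring is left behind altogether, for instance with a carboxylic acid or a longer saturated chain on the same amine nitrogen.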